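Allyl in Place of Methoxy: Expected Cytotoxicity of Compound 4

The compounds below may be only part of what the source reports. "The series", "measured", "known", "first", "only" and "open" are said of these compounds alone.

Compound 1, `Cc1cn([C@H]2C[C@H](O)[C@](CO)(Sc3ccccc3)S2)c(=O)[nH]c1=O`, gives in an ADME assay on M8166 cells (Homo sapiens) for cytotoxicity, read by MTT assay, with a stated time of 4 days (on this read-out lower numbers stand for higher toxicity in this test and higher numbers for lower toxicity in this test), a reading of > 100000 nM, which is a limit of the assay.
Compound 2, `Cc1cn([C@H]2C[C@H](O)[C@](CO)(N=[N+]=[N-])S2)c(=O)[nH]c1=O`, gives in this assay a reading of > 10000 nM, again a limit of the assay.
Compound 3, `CO[C@]1(CO)S[C@@H](n2cc(C)c(=O)[nH]c2=O)C[C@@H]1O`, gives in this assay a reading of > 100000 nM, also a limit of the assay.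

Compound 3 therefore stands at the limit of > 100000 nM in this assay, at which 2 of the 3 values shown sit, while compound 2 sits at the limit of > 10000 nM in this assay, at which 1 of the 3 values shown sits. None of the three compounds yields a number, so the steps among them cannot be sized: a step that the two limits leave unreadable from compound 1 to compound 2, a step that the two limits leave unreadable from compound 1 to compound 3 and a step that the two limits leave unreadable from compound 2 to compound 3 all remain unreadable.

Compound 4, `C=CC[C@]1(CO)S[C@@H](n2cc(C)c(=O)[nH]c2=O)C[C@@H]1O`, has not yet been measured. It differs from compound 3 by allyl in place of methoxy on a saturated ring carbon. The measured steps that bear on this change all end at limits, so they give no size to carry over; what they do show is that three different groups at this ring carbon left the cells unharmed up to the limit.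

Compound 4 is therefore expected to show no readable step in this assay, with a number no higher from compound 3 to compound 4 (the limit leaves the size open) as the likely outcome. The estimate for compound 4 is 100000 nM, in a range from 30000 nM to 300000 nM, and a reading that is again only a limit is expected, because compound 3 sits at the limit of > 100000 nM in this assay, at which 2 of the 3 values shown sit.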

Compound 4, half-maximal cytotoxic concentration: > 100000 nM
Compound 4: no number, only a limit; the forecaster's own chance of this, stated with the estimate: 80%; the middle value sits exactly at the limit.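

Compound 4 again gives only a limit of the assay in this assay, so no step can be read between it and compound 1, compound 2 or compound 3. The compounds shown leave open at what concentration any of them would harm the cells, and whether the groups at this ring carbon differ in cytotoxicity at all.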